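Methoxy to Fluoro: Estimating Compound 3

The source may report more compounds than this note shows. Statements on the series, on what has been measured and on what is new or still open speak of the compounds shown alone.

Compound 1 `COc1cccc(Nc2nc(Cl)nc3[nH]cnc23)c1`: 21000 nM in an assay for activation of histidine kinase 3 (Arabidopsis thaliana), read by a beta-galactosidase reporter; on this read-out higher numbers stand for an effect only at larger amounts of compound and lower numbers for an effect already at smaller amounts
Compound 2 `COc1cccc(Nc2nc(F)nc3[nH]cnc23)c1`: 19000 nM in this assay

Compound 1 stands at the highest of these two numbers, yet compound 2 sits within the scatter of it: a 1.1-fold lower number from compound 1 to compound 2 (0.04 log units; within the scatter). Compound 3 `Fc1cccc(Nc2nc(Cl)nc3[nH]cnc23)c1` differs from compound 1 by fluoro in place of methoxy on an aromatic carbon, meta to a large group. Going by the values given here, the only measured step, a 1.1-fold lower number from compound 1 to compound 2 (0.04 log units; within the scatter), swaps a halogen on the shared core and leaves this ring untouched, so no measured step bears on the change. Compound 3 is therefore expected to land near compound 1, with the estimated step of a 1.2-fold higher number from compound 1 to compound 3 (0.08 log units; within the scatter) carrying wide uncertainty. The estimate for compound 3 in this assay is 25000 nM, spanning 6000 nM to 100000 nM.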

Compound 3, half-maximal effective concentration: 6000 nM
Compound 3: middle estimate off by 4.2-fold (0.62 log units), on the high side, within the range that was stated.
By their numbers in this assay, from the lowest: compound 3; then compounds 2 and 1 (each within the scatter of the next).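

The ring carrying the methoxy is a place where a change shows up in this assay as fluoro in place of methoxy gives a clear shift (a 3.5-fold lower number from compound 1 to compound 3 (0.54 log units; beyond the scatter)), meaning an effect at smaller amounts of compound. The earlier halogen swap on the shared core had stayed within the scatter. No measurement at hand accounts for this shift. Still open, as far as these compounds go, is whether the shift comes from losing methoxy or from gaining fluoro. From the compounds shown here alone, how a hydroxyl, an amine or a chloro would read at this same place also remains unknown.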